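Flipping the Double Bond Geometry of an Oxime Ether

The source may hold more compounds than are shown below. What is called first, only, known or untested is meant among the compounds shown, and "the series" means these compounds.

Of the compounds shown here, two have been measured in a functional assay on HEK293 cells with D(4) dopamine receptor (Homo sapiens) as the target, read by FLIPR; on this read-out lower numbers stand for an effect already at smaller amounts and higher numbers for an effect only at larger amounts of compound. Compound 1 `CO/N=C(/CCN1CCN(c2ccccn2)CC1)c1ccc(Cl)cc1` gives 56.6 nM. Compound 2 `CO/N=C(\CCN1CCN(c2ccccn2)CC1C)c1ccc(Cl)cc1` gives 333 nM, the highest of the two numbers, and its nearest neighbour is compound 1 with a value that lies beyond the usual scatter of this kind of measurement. Among the compounds with values here, the untested compound 3 `CO/N=C(/CCN1CCN(c2ccccn2)CC1C)c1ccc(Cl)cc1` is built from exactly the same atoms and bonds as compound 2; the only change is the two compounds have the same atoms and bonds; at least one stereo element is drawn with a configuration in one of them and without one in the other: 1 of 2 stereo elements differ; a double bond is drawn E in compound 2 and Z in compound 3. Compound 3 therefore carries the same double-bond geometry that compound 1 shows, while keeping the rest of compound 2 unchanged. Within the data shown here, no measured pair isolates this single change, so the size of the step is open. Given that compound 1 reaches 56.6 nM with this geometry, compound 3 is expected to land well below compound 2, at an estimated 90 nM with a range of 30 nM to 300 nM, a step of a 3.7-fold lower number from compound 2 to compound 3 (0.57 log units; beyond the scatter).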

Compound 3, half-maximal effective concentration: 99 nM
The estimate for compound 3 lay 1.1-fold (0.04 log units) below the measured number; the range from low to high includes it.
By their numbers in this assay, from the lowest: compounds 1 and 3 (each within the scatter of the next); then compound 2.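

Switching only the double bond of the oxime ether gives a 3.4-fold lower number from compound 2 to compound 3 (0.53 log units; beyond the scatter) in this assay and so shows that this geometry alone can move the number. Methyl in place of hydrogen on a saturated ring carbon gives a 1.7-fold higher number from compound 1 to compound 3 (0.24 log units; within the scatter) and so leaves no step that can be told apart from the scatter when the double bond has this geometry. Reading the first step as a clean switch of geometry calls for one caution: the fact that one of compounds 2 and 3 is drawn with a defined configuration and the other without, at the place where they differ.

As far as these compounds go, whether the geometry step keeps its size in a compound without the methyl remains open, as does the effect of a larger group on that ring carbon, such as ethyl or hydroxymethyl. From the compounds shown here alone, how an ethoxy group in place of the methoxy on the oxime would read under either geometry is also open.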